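The source may report more compounds than this note shows. Statements on the series, on what has been measured and on what is new or still open speak of the compounds shown alone.

Within the set shown, compound 3 `CCCCCCCCc1ccc(OCC(=O)Cn2nnc(C(=O)OC)n2)cc1` gives 88 nM in an assay on microsomes from brain for inhibition of Fatty-acid amide hydrolase 1 (Rattus norvegicus), read by fluorescence and HPLC, with a stated time of 60 min (a higher number here means a weaker inhibitor, a lower number a stronger inhibitor), the highest of the three numbers: compound 1 `CCCCCCCCc1ccc(OCC(=O)Cn2nnc(-c3cccc(Cl)c3)n2)cc1` gives 24 nM and compound 2 `CCCCCCCCc1ccc(OCC(=O)Cn2nnc(-c3cccc(C(=O)OC)c3)n2)cc1` gives 34 nM. Compound 4 `CCCCCCCCc1ccc(OCC(=O)Cn2nnnc2C(=O)OC)cc1` holds the same atoms as compound 3, joined differently: 5-(methoxycarbonyl)-1H-tetrazol-1-yl in place of 5-(methoxycarbonyl)-2H-tetrazol-2-yl on a saturated chain carbon bound to a carbonyl carbon. The measured steps all concern which group the ring carries, not how the ring is attached to the chain; they ran a 3.7-fold higher number from compound 1 to compound 3 (0.56 log units; beyond the scatter) and a 2.6-fold higher number from compound 2 to compound 3 (0.41 log units; beyond the scatter), with a 1.4-fold higher number from compound 1 to compound 2 (0.15 log units; within the scatter). None bears directly on the change to compound 4, so no step beyond the scatter is expected in this assay, the uncertainty leaning towards a weaker inhibitor. Compound 4 is expected at 110 nM, range 40 nM to 320 nM. The expected step is a 1.3-fold higher number from compound 3 to compound 4 (0.10 log units; within the scatter).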

Compound 4, half-maximal inhibitory concentration: 1000 nM
Compound 4: middle estimate off by 9.1-fold (0.96 log units), on the low side, and the stated range ends below it.
By their numbers in this assay, from the lowest: compounds 1 and 2 (each within the scatter of the next); then compound 3; then compound 4.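

In this assay, the change from 5-(methoxycarbonyl)-2H-tetrazol-2-yl to 5-(methoxycarbonyl)-1H-tetrazol-1-yl, with the same atoms joined differently, gives an 11-fold higher number from compound 3 to compound 4 (1.06 log units; beyond the scatter). Among these compounds, how the ring is joined to the saturated chain carbon therefore counts for more than the group the ring carries, which gave a 3.7-fold higher number from compound 1 to compound 3 (0.56 log units; beyond the scatter). No measurement shown accounts for this difference. Going by these compounds, it remains open whether the 1H-tetrazol-1-yl attachment costs as much when the ring carries 3-chlorophenyl. On these data alone, a carboxylic acid in place of the methyl ester also remains open for both attachments.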